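The compounds below may be only part of what the source reports. "The series", "measured", "known", "first", "only" and "open" are said of these compounds alone.

Measured compounds:
Compound 1, `Clc1ccc(-c2cc(-c3ccco3)cc(-c3ccc(Cl)s3)n2)cc1`: 53.1%
Compound 2, `Clc1ccc(-c2cc(-c3ccoc3)cc(-c3ccc(Cl)s3)n2)cc1`: 2.3%
Compound 3, `Clc1ccc(-c2cc(-c3ccco3)nc(-c3ccc(Cl)s3)c2)o1`: 23.1%

In an assay on isolated protein for inhibition of DNA topoisomerase 1 (Homo sapiens), with a stated time of 30 min, tested at 100 uM (a higher number here means more inhibition at the concentration tested (going by the name of the read-out), a lower number less inhibition), compound 3 stands second highest of the three numbers, beyond the scatter below compound 1 and beyond the scatter above compound 2. Compound 4, `Clc1ccc(-c2cc(-c3ccc(Cl)o3)cc(-c3ccc(Cl)s3)n2)cc1`, is not yet measured; it differs from compound 3 in one place: 4-chlorophenyl in place of furan-2-yl on an aromatic carbon, the new group sitting next to the ring nitrogen of the shared core.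

Among the measured compounds shown here, only one measured step exists, and it concerns a different change: a number 50.8 percentage points lower from compound 1 to compound 2 (beyond the scatter), a large drop on moving from furan-2-yl to furan-3-yl. For the measured compounds named here, no measured step covers furan-2-yl giving way to 4-chlorophenyl, so that step is a weak guide. What the values show is that compound 1, which carries both a 4-chlorophenyl and a furan-2-yl group, gives 53.1% in this assay, the highest number here.

On that basis compound 4 is expected to rise above compound 3, with an estimated step of a number 16.9 percentage points higher from compound 3 to compound 4 (beyond the scatter). Compound 4 is estimated at 40% in this assay, in a range from 10% to 70%.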

Compound 4, a percentage reported as inhibition, at one concentration (the size of the read-out at that concentration, not a potency): 2.2%
Beside the measured number, compound 4's estimate is 37.8 percentage points above it, outside the stated range (below it).
By their numbers in this assay, from the lowest: compounds 4 and 2 (each within the scatter of the next); then compound 3; then compound 1.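

The result shows that, with the 4-chlorophenyl and 5-chlorothiophen-2-yl groups in place, the group at the other position decides the outcome in this assay: a single chloro on the furan-2-yl group of compound 1 gives a number 50.9 percentage points lower from compound 1 to compound 4 (beyond the scatter). The 4-chlorophenyl group therefore does not secure the high number seen for compound 1, since its entry in place of furan-2-yl gives a number 20.9 percentage points lower from compound 3 to compound 4 (beyond the scatter). The 5-chlorofuran-2-yl group of compound 4 also gives no clear difference from the furan-3-yl group of compound 2, with a number 0.1 percentage points lower from compound 2 to compound 4 (within the scatter), so both changes to the furan-2-yl group of compound 1 end at the same low level.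

Nothing in the data shown explains these steps. As far as these compounds go, it remains open whether a methyl group or a fluorine atom in place of this chloro would keep the inhibition of compound 1.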